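Methoxyphenyl for bromophenyl: what cytotoxicity to expect

A few compounds are considered here, and "the series" means these few. Any claim that something is new, unique, unknown or untested is made for them only; others in the source may bear on it.

Three hydrazones built on a shared core have been tested in an ADME assay on MT4 cells (Homo sapiens) for cytotoxicity, read by MTT assay, with a stated time of 4 days; on this read-out higher numbers stand for lower toxicity in this test and lower numbers for higher toxicity in this test. Compound 1 `O=C(COc1cccc2ccccc12)N/N=C/c1ccccc1Br` gives 11.4 ug/mL, and it sits at the low end of the three numbers. Compound 3 `O=C(COc1cccc2ccccc12)N/N=C/c1ccccc1[N+](=O)[O-]` gives 12.2 ug/mL, and the step of a 1.1-fold higher number from compound 1 to compound 3 (0.03 log units; within the scatter) shows that the two are not separated. Within the data shown here, compound 2 `C/C(=N\NC(=O)COc1cccc2ccccc12)c1ccc(O)cc1O` gives 59.9 ug/mL, which is the one number that stands clearly apart from compound 1.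

Compound 4 `COc1ccc(/C=N/NC(=O)COc2cccc3ccccc23)cc1` has not yet been measured in this assay. It differs from compound 1 by 4-methoxyphenyl in place of 2-bromophenyl on a carbon with a double bond to nitrogen. Among the measured compounds shown here, no measured step swaps one phenyl group for another in the way this change does: the one step on hand, from compound 1 to compound 3, exchanges only a single substituent on the ring and stays within the scatter. Compound 2, with a differently substituted ring, gives the higher number, but it also carries other changes, so it offers only a loose hint.

For compound 4 a step of about a 1.6-fold higher number from compound 1 to compound 4 (0.20 log units; within the scatter) is therefore expected, which is small and at most a modest move upward. Compound 4 is estimated at 18 ug/mL, with a range from 7 ug/mL to 45 ug/mL.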

Compound 4, half-maximal cytotoxic concentration: 76.9 ug/mL
The estimate for compound 4 lay 4.3-fold (0.63 log units) below the measured number; the measured number lies above the stated range.
By their numbers in this assay, from the lowest: compounds 1 and 3 (each within the scatter of the next); then compounds 2 and 4 (each within the scatter of the next).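

Replacing 2-bromophenyl with 4-methoxyphenyl on a carbon with a double bond to nitrogen gives a 6.7-fold higher number from compound 1 to compound 4 (0.83 log units; beyond the scatter) in this assay, so compound 4 is less toxic than compound 1 in this test. The earlier exchange at this ring, a 1.1-fold higher number from compound 1 to compound 3 (0.03 log units; within the scatter), did not separate its two compounds, whereas this result shows that a change of the aromatic group at this position can move the number beyond the scatter. No measurement shown here explains the shift.

The step changes both the substituent and its numbered place on the ring, so the compounds shown cannot tell which of the two matters. From the compounds shown here alone, how an amine or a carboxylic acid on the same phenyl ring would affect the number also remains open.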